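This account rests on a few compounds, and the source may have more. Where it says the series, first, only, none or still open, it means among the compounds named here.

Compounds measured in a functional assay on HepG2 cells (Homo sapiens) for cytotoxicity, read by MTT assay, with a stated time of 72 h; a lower number here means a stronger inhibitor, a higher number a weaker inhibitor:
compound 1 `Cc1cc(=O)n(-c2ccccc2OC(F)(F)F)nc1C(=O)Nc1ccc(Oc2ncnc3ccsc23)cc1`, 25000 nM
compound 2 `Cc1cc(=O)n(-c2cccc(F)c2)nc1C(=O)Nc1ccc(Oc2ncnc3ccsc23)cc1`, 10200 nM
compound 3 `Cc1cc(=O)n(-c2ccc(F)cc2)nc1C(=O)Nc1ccc(Oc2ncnc3ccsc23)cc1`, 2110 nM

Compound 1 gives the highest number of the three. Its nearest neighbour is compound 2, a 2.5-fold lower number from compound 1 to compound 2 (0.39 log units; beyond the scatter); the furthest is compound 3, a 12-fold lower number from compound 1 to compound 3 (1.07 log units; beyond the scatter), while between them a 4.8-fold lower number from compound 2 to compound 3 (0.68 log units; beyond the scatter). Compound 4 `Cc1cc(=O)n(-c2ccccc2OC(F)(F)F)nc1C(=O)Nc1ccc(Oc2ncnc3ccsc23)c(F)c1` differs from compound 1 by fluoro in place of hydrogen on an aromatic carbon, on an aromatic carbon of a six-membered aromatic ring of carbon only. Going by the values given here, none of the measured steps touches that ring; all three vary the aryl on the aromatic nitrogen, so no measured step bears directly on this change. He therefore expects no step beyond the scatter, a 1.3-fold lower number from compound 1 to compound 4 (0.10 log units; within the scatter). For compound 4 he estimates 20000 nM in this assay, with a range of 7000 nM to 55000 nM.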

Compound 4, half-maximal inhibitory concentration: 15700 nM
Estimate against measurement, compound 4: 1.3-fold (0.11 log units) above; the measured number falls inside the stated range.
By their numbers in this assay, from the lowest: compound 3; then compounds 2, 4 and 1 (each within the scatter of the next, the first and the last beyond it).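

The earlier steps shown here varied only the aryl on the aromatic nitrogen. Here, fluoro in place of hydrogen on a six-membered aromatic ring of carbon only, ortho to a large group and meta to a large group, gives a 1.6-fold lower number from compound 1 to compound 4 (0.20 log units; within the scatter) in this assay, so with the 2-(trifluoromethoxy)phenyl group in place, this change cannot be told from the scatter. Nothing available explains this result.

As far as these compounds go, whether fluoro would do the same with the 4-fluorophenyl group of compound 3 stays open. So does the effect of a methoxy group, an amine or a carboxylic acid on this carbon.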